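Moving the ethyl around the imidazole of compound 3

This account rests on a few compounds, and the source may have more. Where it says the series, first, only, none or still open, it means among the compounds named here.

Compound 3, `CCc1cnc(-c2ccccc2CCc2cc(Br)ccc2OC)n1C`, was measured in an assay on isolated protein for binding affinity to Melanocortin receptor 4 (Homo sapiens) (a lower number here means a stronger inhibitor, a higher number a weaker inhibitor), and gave 320 nM. Its companions sit close by: compound 1, `CCn1ccnc1-c1cccc(Cl)c1CCc1cc(Br)ccc1OC`, gives 310 nM in this assay, and compound 2, `COc1ccc(Br)cc1CCc1ccccc1-c1ncc(C)n1C`, gives 180 nM; both numbers lie within the scatter of the number for compound 3, so no order among the three can be read. Compound 4, `CCc1cn(C)c(-c2ccccc2CCc2cc(Br)ccc2OC)n1`, differs from compound 3 by 4-ethyl-1-methyl-1H-imidazol-2-yl in place of 5-ethyl-1-methyl-1H-imidazol-2-yl on an aromatic carbon. For the measured compounds named here, the only measured step that touches this part of the molecule is a 1.8-fold higher number from compound 2 to compound 3 (0.25 log units; within the scatter), a change that stayed within the scatter. Going by the values given here, no measured pair shows what happens when the ethyl changes its place on the imidazole while everything else is kept, so the expectation for compound 4 rests on the quiet behaviour of this region alone. The step from compound 3 to compound 4 is therefore expected to be small, a 1.1-fold higher number from compound 3 to compound 4 (0.04 log units; within the scatter), with no direction beyond the scatter. Compound 4 is estimated to give 350 nM, with a range from 120 nM to 1000 nM.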

Compound 4, inhibition constant: 690 nM
Compound 4: middle estimate off by 2.0-fold (0.29 log units), on the low side, within the range that was stated.
By their numbers in this assay, from the lowest: compounds 2, 1 and 3 (each within the scatter of the next); then compound 4.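

Moving the ethyl, with 4-ethyl-1-methyl-1H-imidazol-2-yl in place of 5-ethyl-1-methyl-1H-imidazol-2-yl, gives the first step at this position in this assay that lies beyond the scatter (a 2.2-fold higher number from compound 3 to compound 4 (0.33 log units; beyond the scatter)), although the two groups hold the same atoms joined differently. Against the 1,5-dimethyl-1H-imidazol-2-yl group the same kind of change also lies beyond the scatter (a 3.8-fold higher number from compound 2 to compound 4 (0.58 log units; beyond the scatter)), so this region is less quiet than the earlier step (a 1.8-fold higher number from compound 2 to compound 3 (0.25 log units; within the scatter)) alone suggested. Nothing measured alongside these compounds bears on the reason for this shift.

On these data alone, whether a propyl chain or an amine in place of the ethyl on the imidazole would read like compound 3 or like compound 4 remains open. As far as these compounds go, it is also open whether the step would hold on the chlorinated core of compound 1.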